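The source may report more compounds than this note shows. Statements on the series, on what has been measured and on what is new or still open speak of the compounds shown alone.

Compounds measured so far:

Compound 1, `COc1ccc(/C=C/C(=O)Nc2cc(C(=O)c3cc(OC)c(OC)c(OC)c3)ccc2OC)cc1`, gives 11100 nM in a functional assay on PC-3 cells (Homo sapiens) for cytotoxicity, read by MTT assay, with a stated time of 72 h; on this read-out lower numbers stand for stronger inhibition and higher numbers for weaker inhibition.
Compound 2, `COc1cc(C(=O)c2cc(OC)c(OC)c(OC)c2)cc(NC(=O)/C=C/c2cc(OC)c(OC)c(OC)c2)c1OC`, gives 4800 nM in this assay.
Compound 3, `COc1ccc(/C=C/C(=O)Nc2cc(C(=O)c3cc(OC)c(OC)c(OC)c3)cc(OC)c2OC)cc1OC`, gives 5400 nM in this assay.

Compound 3 stands second highest of the three numbers. Its nearest neighbour is compound 2, from which it differs by one methoxy group: a 1.1-fold higher number from compound 2 to compound 3 (0.05 log units; within the scatter). The gap to compound 1 is larger, beyond the scatter, but the two structures differ in two places, so their values alone cannot be traced to a single change.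

Compound 4, `COc1ccc(/C=C/C(=O)Nc2cc(C(=O)c3cc(OC)c(OC)c(OC)c3)cc(OC)c2OC)cc1`, arises from compound 3 by hydrogen in place of methoxy on an aromatic carbon. For the measured compounds named here, the only measured step that bears on this change is a 1.1-fold higher number from compound 2 to compound 3 (0.05 log units; within the scatter), which also removed a methoxy from the same aryl ring and stayed within the scatter. The step from compound 3 to compound 4 is therefore expected to be small as well, perhaps drifting slightly toward the higher number of compound 1, as a 1.2-fold higher number from compound 3 to compound 4 (0.08 log units; within the scatter). Compound 4 is estimated at 6500 nM, within 3000 nM to 14000 nM.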

Compound 4, half-maximal inhibitory concentration: 6300 nM
Compound 4: the middle estimate sits 1.0-fold (0.01 log units) above what was measured; measured number inside the range.
By their numbers in this assay, from the lowest: compounds 2, 3, 4 and 1 (each within the scatter of the next, the first and the last beyond it).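

Replacing the 3,4-dimethoxyphenyl group with 4-methoxyphenyl shows that this methoxy can go with little consequence in this assay, with a 1.2-fold higher number from compound 3 to compound 4 (0.07 log units; within the scatter). The step from 3,4,5-trimethoxyphenyl to 4-methoxyphenyl also stays within the scatter, with a 1.3-fold higher number from compound 2 to compound 4 (0.12 log units; within the scatter), so this aryl group tolerates losing more than one methoxy in these compounds. On the other side of compound 4, placing a methoxy on an aromatic carbon gives a 1.8-fold lower number from compound 1 to compound 4 (0.25 log units; within the scatter), and the exchange of methoxy and hydrogen reads alike on two cores: the same change on two cores in this assay, a 1.1-fold higher number (0.05 log units; within the scatter) from compound 2 to compound 3 and a 1.8-fold higher number (0.25 log units; within the scatter) from compound 4 to compound 1, 1.6-fold (0.19 log units) apart, within the scatter of two such steps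

Methoxy and hydrogen are the only groups shown at this position, so what a hydroxy group or an amine would do there remains open. Also open, on these data alone, is the number for a plain phenyl group in place of 4-methoxyphenyl.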